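This account rests on a few compounds, and the source may have more. Where it says the series, first, only, none or still open, it means among the compounds named here.

Going by the values given here, in a functional assay on SW-620 cells (Homo sapiens) for inhibition, read by MTT assay, with a stated time of 48 h (on this read-out higher numbers stand for weaker inhibition and lower numbers for stronger inhibition), compound 3 `Cc1ccc(COc2ccc(C(=O)NC(=O)Nc3ccc(C)c(-c4nc5ccccc5[nH]4)c3)cc2)cc1` gives 26000 nM and stands at the upper end of the three numbers so far: the step of a 1.7-fold higher number from compound 1 to compound 3 (0.23 log units; within the scatter) lies within the scatter, and only the step of a 2.7-fold higher number from compound 2 to compound 3 (0.43 log units; beyond the scatter) is modest but beyond it. Compound 1 `Cc1ccc(NC(=O)NC(=O)c2ccc(OCc3ccc(C(F)(F)F)cc3)cc2)cc1-c1nc2ccccc2[nH]1` gives 15300 nM and compound 2 `Cc1ccc(NC(=O)NC(=O)c2ccc(OCc3cccc(C(F)(F)F)c3)cc2)cc1-c1nc2ccccc2[nH]1` gives 9640 nM. Compound 4 `Cc1ccc(NC(=O)NC(=O)c2ccc(OCc3ccc(F)cc3)cc2)cc1-c1nc2ccccc2[nH]1` differs from compound 3 by fluoro in place of methyl on an aromatic carbon, on an aromatic carbon of a six-membered aromatic ring of carbon only, para to a large group; read one bond further out, 4-methylbenzyl becomes 4-fluorobenzyl. Among the compounds with values here, the steps that bear on this carbon are a swap of trifluoromethyl for methyl there and a move of trifluoromethyl around the ring, a 1.6-fold lower number from compound 1 to compound 2 (0.20 log units; within the scatter), both within the scatter; the combined change alone reached beyond it. A small substituent change at this carbon is therefore expected to shift this assay little, with no step beyond the scatter. The expected step for compound 4 is a 1.4-fold lower number from compound 3 to compound 4 (0.16 log units; within the scatter). For compound 4 the estimate is 18000 nM, with a range from 7000 nM to 45000 nM.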

Compound 4, half-maximal inhibitory concentration: 35100 nM
Estimate against measurement, compound 4: 2.0-fold (0.29 log units) below; the measured number falls inside the stated range.
By their numbers in this assay, from the lowest: compounds 2, 1, 3 and 4 (each within the scatter of the next, the first and the last beyond it).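

In this assay, fluoro and methyl on this aromatic carbon, para to a large group, cannot be told apart (a 1.4-fold higher number from compound 3 to compound 4 (0.13 log units; within the scatter)). Fluoro and trifluoromethyl at the same carbon do separate (a 2.3-fold higher number from compound 1 to compound 4 (0.36 log units; beyond the scatter)), making this the only swap at this carbon alone to pass the scatter, since trifluoromethyl and methyl stayed within it. The widest step in the set, still modest, also ends at the 4-fluorobenzyl compound (a 3.6-fold higher number from compound 2 to compound 4 (0.56 log units; beyond the scatter)), and no measurement offered here explains any of these steps.

On these data alone, whether an amine or a carboxylic acid on this carbon would move the number further remains open. Also open, as far as these compounds go, is how fluoro or methyl would read on the ring carbon that carries trifluoromethyl in compound 2.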